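Aryl swap on the amide of compound 3

This account rests on a few compounds, and the source may have more. Where it says the series, first, only, none or still open, it means among the compounds named here.

In a functional assay on A549 cells (Homo sapiens) for cytotoxicity, read by MTT assay, with a stated time of 72 h (on this read-out lower numbers stand for stronger inhibition and higher numbers for weaker inhibition), compound 1 (`COc1ccc(NC(=O)CN2CCN(c3nnc(Cc4ccncc4)c4ccccc34)CC2)cc1OC`) gives 26500 nM and compound 2 (`Cc1ccc(NC(=O)CN2CCN(c3nnc(Cc4ccncc4)c4ccccc34)CC2)c(C)c1`) gives 45000 nM. Compound 3 (`COc1ccc(NC(=O)CN2CCN(c3nnc(Cc4ccccc4)c4ccccc34)CC2)cc1OC`) has no number and is reported as "not active" (no number reported), so it holds no place on the numeric scale.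

Compound 4 (`Cc1cccc(Cl)c1NC(=O)CN1CCN(c2nnc(Cc3ccccc3)c3ccccc23)CC1`) comes from compound 3 by one change: 2-chloro-6-methylphenyl in place of 3,4-dimethoxyphenyl on an amide-type nitrogen. Among the compounds with values here, the only measured step that bears on this is the replacement of 3,4-dimethoxyphenyl by 2,4-dimethylphenyl at the same kind of nitrogen, a 1.7-fold higher number from compound 1 to compound 2 (0.23 log units; within the scatter), which lies within the scatter. With no number for compound 3, a step cannot be sized directly. On the evidence of that single swap, no shift beyond the scatter is expected in this assay, in either direction, and a second report without a number remains quite possible. If a number is obtained, compound 4 is expected at 45000 nM, within an estimated range of 15000 nM to 120000 nM.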

Compound 4, half-maximal inhibitory concentration: 7420 nM
Beside the measured number, compound 4's estimate is 6.1-fold (0.78 log units) above it, and the stated range ends above it.
By their numbers in this assay, from the lowest: compound 4; then compounds 1 and 2 (each within the scatter of the next).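

Within the data shown here, compound 4 gives 7420 nM, but compound 3 is reported as not active with no number, so no step between compound 3 and compound 4 can be read. The compounds shown leave open how 2-chloro-6-methylphenyl and 3,4-dimethoxyphenyl compare numerically on the same core. No supporting data explain compound 4's value.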